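Ortho-hydroxy on the aniline of compound 1

A few compounds are considered here, and "the series" means these few. Any claim that something is new, unique, unknown or untested is made for them only; others in the source may bear on it.

Among the compounds with values here, compound 1 `C#CCSc1nc(Nc2ccccc2)c2ccncc2n1` gives 29400 nM in a functional assay on HepG2 cells (Homo sapiens) for inhibition, read by MTT assay, with a stated time of 72 h (a higher number here means a weaker inhibitor, a lower number a stronger inhibitor), the highest of the three numbers so far. Compound 2 `C#CCSc1nc(Nc2cccc(OC)c2)c2ccncc2n1` gives 920 nM and compound 3 `C#CCSc1nc(Nc2cc(OC)c(OC)c(OC)c2)c2ccncc2n1` gives 14200 nM in this assay; the values of compound 1 and compound 3 sit beyond the scatter of each other, compound 3 lower.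

Compound 4 `C#CCSc1nc(Nc2ccccc2O)c2ccncc2n1` differs from compound 1 by hydroxy in place of hydrogen on an aromatic carbon. Within the data shown here, the one measured single step on this core is a 32-fold lower number from compound 1 to compound 2 (1.50 log units; beyond the scatter), a methoxy entering the aniline ring; it is large. That step concerns a different group at a different place, so it bears only loosely on compound 4. The added hydroxy brings one hydrogen-bond donor and one acceptor where the methoxy brought only an acceptor, and it enters ortho to a large group rather than where the methoxy of compound 2 sits.

Given the gain from compound 1 to compound 2 as the only lead, compound 4 is expected to improve on compound 1, but by less: an estimated 2.9-fold lower number from compound 1 to compound 4 (0.47 log units; beyond the scatter), giving an estimate of 10000 nM with a range of 2500 nM to 40000 nM.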

Compound 4, half-maximal inhibitory concentration: > 80000 nM
Compound 4 ended at the assay's limit (the forecaster's own chance of this, stated with the estimate: 10%); at least 8.0-fold (0.90 log units) between middle value and limit.
By their numbers in this assay, from the lowest: compound 2; then compound 3; then compound 1. At a limit, above all of these: compound 4.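

In this assay the reading of compound 4 is a limit of the assay and not a number: the limit of > 80000 nM in this assay, at which 1 of the 4 values shown sits.

The new step is an at least 2.7-fold higher number from compound 1 to compound 4 (0.43 log units; beyond the scatter), so hydroxy in place of hydrogen on an aromatic carbon, ortho to a large group, moves the number the opposite way to the methoxy in a 32-fold lower number from compound 1 to compound 2 (1.50 log units; beyond the scatter). A single added group on the aniline ring of compound 1 can therefore either lower or raise the number, and this position with this group gives the only rise among the single steps shown.

The compounds shown leave open whether the rise follows the hydroxy itself or its place on the ring. An amine or a fluoro group in that same place, or a hydroxy where compound 2 carries its methoxy, would bear on this.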